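This account rests on a few compounds, and the source may have more. Where it says the series, first, only, none or still open, it means among the compounds named here.

In an ADME assay on microsomes from liver (Mus musculus, strain CD1) for metabolic stability, read by LC-MS, using NADPH, with a stated time of 30 min, tested at 3 uM (a lower number here means that less of the compound is left, a higher number that more of the compound is left), compound 1 (`CN1Cc2cc(-c3ccc(-c4cncc(NS(=O)(=O)c5ccc(F)cc5F)c4)s3)cnc2C1=O`) reads 100% and compound 2 (`COc1ncc(-c2ccc(-c3cnc4c(c3)CN(C)C4=O)s2)cc1NS(=O)(=O)c1ccccc1[N+](=O)[O-]`) reads 95% on the same scale. The two numbers lie within the usual scatter of each other, so compound 2 stands level with compound 1, and nothing separates them. Among the measured compounds shown here, no step between measured compounds that differ in one place is available yet, so no measured change can serve as a yardstick.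

For the measured compounds named here, compound 3 (`COc1ncc(-c2ccc(-c3cnc4c(c3)CN(C)C4=O)s2)cc1NS(=O)(=O)c1ccc(F)cc1F`) has no number so far. It departs from compound 2 on a sulfonyl sulfur, with 2,4-difluorophenyl in place of 2-nitrophenyl (2,4-difluorophenyl in place of 2-nitrophenyl on a sulfonyl sulfur). The expectation therefore rests on the two values alone: compound 1 at 100% and compound 2 at 95% both leave most of the compound remaining. No change beyond the scatter is expected, and the estimated step (a number 3 percentage points lower from compound 2 to compound 3 (within the scatter)) is small, with a slight leaning downward at most. Compound 3 is expected at 92% (estimated range 78% to 100%) in this assay when its measurement arrives.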

Compound 3, percent of the compound remaining: 100%
Estimate against measurement, compound 3: 8 percentage points below, and the stated range covers the measured number.
By their numbers in this assay, from the lowest: compounds 2, 1 and 3 (each within the scatter of the next).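

In this assay, among the compounds shown here, the first one-place comparison at the sulfonyl sulfur gives a number 5 percentage points higher from compound 2 to compound 3 (within the scatter) with 2,4-difluorophenyl in place of 2-nitrophenyl, so this exchange leaves the read-out level and the nitro group is not needed to hold it there. The series also gains a second one-place comparison, where methoxy in place of hydrogen on an aromatic carbon gives no change at the digits printed from compound 1 to compound 3 (within the scatter) and the read-out again stays level, so neither change shown separates these compounds. No measured finding is available to account for either result.

With compound 1, compound 2 and compound 3 all lying within the scatter of each other, the compounds shown leave open whether a non-aromatic group such as methyl or cyclopropyl on the sulfonyl sulfur, or a phenyl carrying a carboxylic acid or an amine, would keep the same standing in this assay as 2,4-difluorophenyl. They also leave open whether a longer chain such as ethoxy or propoxy in place of methoxy on that aromatic carbon would stay level with compound 3 at 100% in this read-out.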